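A few compounds are considered here, and "the series" means these few. Any claim that something is new, unique, unknown or untested is made for them only; others in the source may bear on it.

Of the compounds shown here, three have been measured in an assay on isolated protein for binding affinity to 5-hydroxytryptamine receptor 1B (Homo sapiens); a lower number here means a stronger inhibitor, a higher number a weaker inhibitor. Compound 1 `CCN1[C@H](C)CN(c2cc3c(cc2OC)CCN3C(=O)c2ccc(-c3cccc(C)n3)c3ccccc23)C[C@@H]1C` gives 3.98 nM, compound 2 `COc1cc2c(cc1N1C[C@@H](C)N(C)[C@@H](C)C1)N(C(=O)c1cccc(Cl)c1Cl)CC2` gives 12.6 nM, and compound 3 `COc1cc2c(cc1N1C[C@@H](C)N[C@@H](C)C1)N(C(=O)c1ccc(-c3ccc(C(C)=O)cc3C)cc1)CC2` gives 3.16 nM. Compound 3 thus shows the lowest of the three numbers, but its gap to compound 1 falls within the usual scatter, so the two cannot be ranked against each other; only compound 2 stands clearly apart, with a number beyond the scatter above that of compound 3.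

Compound 4 `COc1cc2c(cc1N1C[C@@H](C)N[C@@H](C)C1)N(C(=O)c1ccc(-c3cc(C)ncc3C)cc1)CC2` differs from compound 3 in one place: 2,5-dimethylpyridin-4-yl in place of 4-acetyl-2-methylphenyl on an aromatic carbon, para to a large group on the shared core. Among the measured compounds shown here, no measured pair in this set isolates such a swap, so the expectation rests on the shared core and on the aromatic group that replaces the acetyl-bearing ring. Compound 1, which also carries a methyl-substituted pyridinyl, gives 3.98 nM in this assay, close to compound 3. The step is therefore expected to be a 1.6-fold higher number from compound 3 to compound 4 (0.20 log units; within the scatter), none beyond the scatter. Compound 4 is estimated at 5 nM, with a range from 1.6 nM to 16 nM.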

Compound 4, inhibition constant: 7.94 nM
Estimate against measurement, compound 4: 1.6-fold (0.20 log units) below, and the stated range covers the measured number.
By their numbers in this assay, from the lowest: compounds 3, 1, 4 and 2 (each within the scatter of the next, the first and the last beyond it).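

Among the compounds shown here, the swap of 4-acetyl-2-methylphenyl for 2,5-dimethylpyridin-4-yl, on an aromatic carbon para to a large group, gives a 2.5-fold higher number from compound 3 to compound 4 (0.40 log units; beyond the scatter) in this assay; this is the first single-place step in the set, and it shows that this position responds to the group it carries, though only modestly. The step replaces a six-membered aromatic ring of carbon only with one holding a hetero atom and removes the acetyl in the same move, so the two changes cannot be told apart. Nothing at hand accounts for the rise in the number.

Going by these compounds, whether the ring nitrogen or the lost acetyl carries the step remains open, and an unsubstituted phenyl or an acetyl-bearing pyridinyl at this position would separate them. On these data alone, how an amine or a carboxylic acid would read here also remains unknown.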